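Pentafluorophenyl sulfonyl in place of nitrophenyl sulfonyl

The source may report more compounds than this note shows. Statements on the series, on what has been measured and on what is new or still open speak of the compounds shown alone.

Compound 1 `COc1ccc(-c2cc(=O)c3c(OC)cc(OC)cc3n2C)cc1` gives 30000 nM in a functional assay on KOPN-8 cells (Homo sapiens) for antiproliferative activity, with a stated time of 72 h; a higher number here means that more compound is needed for the effect, a lower number that less compound is needed.
Compound 2 `COc1ccc(-c2c(I)c(=O)c3c(OC)cc(OC)cc3n2S(=O)(=O)c2ccc(OC)cc2)cc1` gives 8580 nM in this assay.
Compound 3 `COc1ccc(-c2cc(=O)c3c(OC)cc(OC)cc3n2S(=O)(=O)c2cccc([N+](=O)[O-])c2)cc1` is reported in this assay only as a limit of the assay, > 39600 nM.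

The three measured compounds share one core and differ in the group on the ring nitrogen and in one ring position. Compound 1 and compound 2 have numbers, and compound 2 needs less compound than compound 1. For compound 3 there is no number at all, only (the limit of > 39600 nM in this assay, at which 1 of the 3 values shown sits), so compound 3 stands at the weak end of what this assay can report.

Compound 4 `COc1ccc(-c2cc(=O)c3c(OC)cc(OC)cc3n2S(=O)(=O)c2c(F)c(F)c(F)c(F)c2F)cc1` has not been measured. It differs from compound 3 by one change: 2,3,4,5,6-pentafluorophenyl in place of 3-nitrophenyl on a sulfonyl sulfur. Among the compounds with values here, no pair among the measured compounds differs in exactly one place, so no measured step guides this change directly. The expectation is therefore a step of no clear direction, within the usual scatter, and compound 4 is expected to stay weak, with an at least 1.3-fold lower number from compound 3 to compound 4 (0.12 log units; that floor lies within the scatter) as the assumed step. Compound 4 is estimated at 30000 nM, between 8000 nM and 80000 nM.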

Compound 4, half-maximal effective concentration: > 34400 nM
Compound 4 ended at the assay's limit; the forecaster's own chance of this, stated with the estimate: 50%; middle value at least 1.1-fold (0.05 log units) away from the limit.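

Within the data shown here, compound 3 and compound 4 are both reported in this assay only as limits, not as numbers, so no step between them can be read. On these data alone, whether 2,3,4,5,6-pentafluorophenyl or 3-nitrophenyl on the sulfonyl sulfur needs less compound stays open.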